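From a Three-Membered Ring to an Open Chain

The source may report more compounds than this note shows. Statements on the series, on what has been measured and on what is new or still open speak of the compounds shown alone.

Within the data shown here, compound 2 `CC(C)c1onc(-c2c(Cl)cccc2Cl)c1COc1ccc(-c2nc3ccc(C(=O)O)cc3n2C2CC2)cc1` gives 117 nM in an assay on isolated protein for agonist activity at Bile acid receptor (Homo sapiens), read by TR-FRET (a lower number here means that less compound is needed, a higher number that more compound is needed for the effect), the only number this set provides. For compound 1 `CC(C)c1onc(-c2c(Cl)cccc2Cl)c1COc1ccc(-c2nc3ccc(C(=O)O)cc3n2CC2CCCCC2)c(F)c1` the result in this assay reads "not determined" (no result reported). Compound 3 `CC(C)c1onc(-c2c(Cl)cccc2Cl)c1COc1ccc(-c2nc3ccc(C(=O)O)cc3n2C(C)C)cc1` differs from compound 2 by isopropyl in place of cyclopropyl on an aromatic nitrogen. Among the measured compounds shown here, no measured pair shows what such a change does here, so the step from compound 2 to compound 3 is expected to stay within the usual scatter, with no direction favoured. Compound 3 is accordingly estimated at 130 nM, within a range from 50 nM to 350 nM in this assay. That estimate means an expected step of a 1.1-fold higher number from compound 2 to compound 3 (0.05 log units; within the scatter).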

Compound 3, half-maximal effective concentration: 56.7 nM
Compound 3: the middle estimate sits 2.3-fold (0.36 log units) above what was measured; measured number inside the range.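

In this assay the position on the aromatic nitrogen now has its first measured step: replacing the three-membered ring with isopropyl, at an unchanged heavy-atom count, brings a 2.1-fold lower number from compound 2 to compound 3 (0.31 log units; beyond the scatter). The assay therefore distinguishes a cyclopropyl ring from an open group of the same three carbons at this position. No available evidence explains this difference. As far as these compounds go, it remains open how a longer chain such as n-butyl, or a more branched group such as tert-butyl, would fare here. Compound 1 has no reported result, so it adds nothing on larger groups.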